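Moving the Chlorine: From Compound 3 to Compound 4

This account rests on a few compounds, and the source may have more. Where it says the series, first, only, none or still open, it means among the compounds named here.

Of the compounds shown here, three have so far been tested in a functional assay on the whole organism (strain Swiss) with Mus musculus as the target, in the maximal electroshock model, with a stated time of 1 h, at a dose of 300 mg/kg by the intraperitoneal route; a lower number here means a weaker effect, a higher number a stronger effect of the compound at the dose given. Compound 1 `CCC(C(=O)N1CCOCC1)N1C(=O)CCC1=O` gives 0% in this assay. Compound 2 `CCC(C(=O)N1CCN(c2ccc(Cl)cc2)CC1)N1C(=O)CCC1=O` gives 25%. Compound 3 `CC(C(=O)N1CCN(c2ccc(Cl)cc2)CC1)N1C(=O)CCC1=O` gives 0%. Compound 3 thus stands level with compound 1 at the digits reported, and together these two are the lowest of the three numbers, while compound 2 sits above them. Within the data shown here, the only step measured between neighbours is a number 25 percentage points lower from compound 2 to compound 3 (beyond the scatter), where a hydrogen replaces a methyl on the saturated chain carbon; it is modest but beyond the scatter.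

Compound 4 `CC(C(=O)N1CCN(c2ccccc2Cl)CC1)N1C(=O)CCC1=O` differs from compound 3 only in the aromatic ring that the amine nitrogen in the ring carries: 2-chlorophenyl in place of 4-chlorophenyl on an amine nitrogen in a ring. Both rings hold the same atoms, joined differently. Among the measured compounds shown here, no measured step concerns this aromatic ring; the one measured step, a number 25 percentage points lower from compound 2 to compound 3 (beyond the scatter), changes a different part of the molecule and says nothing about where the chlorine sits. With no comparison to draw on, compound 4 is expected to show no step beyond the scatter, namely a number 5 percentage points higher from compound 3 to compound 4 (within the scatter). Compound 4 is therefore estimated at 5%, with a range from 0% to 25%.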

Compound 4, a percentage reported as activity, at one dose (the size of the read-out at that dose, not a potency): 25%
Beside the measured number, compound 4's estimate is 20 percentage points below it, and the stated range covers the measured number.
By their numbers in this assay, from the lowest: compounds 1 and 3 (each within the scatter of the next); then compounds 2 and 4 (each within the scatter of the next).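

In this assay, exchanging 4-chlorophenyl for 2-chlorophenyl on the amine nitrogen in a ring gives a number 25 percentage points higher from compound 3 to compound 4 (beyond the scatter), so where the chlorine sits on the aromatic ring changes the read-out, even though the two groups have the same atoms and the same counts. The earlier measured step came from a change on the saturated chain carbon, while this one leaves that chain alone, which makes the aromatic ring a second place in these molecules where a single change moves the read-out beyond the scatter. Nothing measured here explains why the position of the chlorine has this effect.

Still open, on these data alone, is whether the chlorine is needed at all, since a plain phenyl group, or a fluorine or a methoxy group in its place, could give a different read-out from 2-chlorophenyl. Also open, as far as these compounds go, is what 2-chlorophenyl does when joined to the longer chain of compound 2, and, as each number is a read-out at one dose, how the compounds would compare across a range of doses.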